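The source may hold more compounds than are shown below. What is called first, only, known or untested is meant among the compounds shown, and "the series" means these compounds.

The study covers three ureas built on one shared core. Compound 1 `Cc1cc(NC(=O)Nc2ccc(F)cc2)c2ccccc2n1` was tested in an ADME assay on HepG2 cells (Homo sapiens) for cytotoxicity, with a stated time of 72 h; a lower number here means that less compound is needed, a higher number that more compound is needed for the effect. In this assay compound 1 gives only a limit, > 25000 nM, not a number. Compound 2 `COc1cccc(NC(=O)Nc2cc(C)nc3ccccc23)c1` was tested in the same way. In this assay compound 2 likewise reaches only a limit, > 25000 nM. Both values therefore sit at the same place, namely (the limit of > 25000 nM in this assay, at which 2 of the 2 values shown sit), so nothing separates compound 1 from compound 2 on these numbers. Compound 3 `Cc1cc(NC(=O)Nc2cccc(F)c2)c2ccccc2n1` has not yet been measured. It differs from compound 2 in one place: fluoro in place of methoxy on an aromatic carbon. Within the data shown here, with both neighbours at the limit, no step between measured compounds can be drawn. The step that the limit leaves unreadable from compound 2 to compound 3 is expected to show no change beyond the scatter. Compound 3 is therefore estimated at 30000 nM, within a range from 15000 nM to 60000 nM, most likely again reported as a limit.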

Compound 3, half-maximal effective concentration: > 25000 nM
Compound 3: a limit, no number; the forecaster's own chance of this, stated with the estimate: 80%; the middle value is on the limit's open side.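

Compound 3 also gives only a limit, so the steps to it from compound 1 and from compound 2 cannot be read in this assay: the limit of > 25000 nM in this assay, at which 3 of the 3 values shown sit.

The compounds shown leave open how the three ureas differ in this assay, and at what concentration each would reach its half-maximal effect.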